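Moving a hydroxyl around the ring: cytotoxicity in HEL cells

The source may report more compounds than this note shows. Statements on the series, on what has been measured and on what is new or still open speak of the compounds shown alone.

Measured compounds:
- compound 1, `O=C(COc1cccc2ccccc12)N/N=C/c1ccc([N+](=O)[O-])cc1`: 20 ug/mL
- compound 2, `C/C(=N\NC(=O)COc1cccc2ccccc12)c1ccc(O)cc1`: 20 ug/mL

In an ADME assay on HEL cells (Homo sapiens) for cytotoxicity (a higher number here means that more compound is tolerated, a lower number that less compound is tolerated), compound 1 gives 20 ug/mL. In this assay compound 2 gives 20 ug/mL. Compound 2 thus stands level with compound 1 at the digits printed, and the gap between the two lies within the usual scatter of repeated measurements, so nothing can be said about one being better tolerated than the other.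

Compound 3, `C/C(=N\NC(=O)COc1cccc2ccccc12)c1ccccc1O`, has not yet been measured. It has the same atoms as compound 2, joined differently: 2-hydroxyphenyl in place of 4-hydroxyphenyl on a carbon with a double bond to nitrogen. The hydroxyphenyl group still hangs on the carbon with a double bond to nitrogen; only the position of the hydroxyl on that ring moves.

For the measured compounds named here, no step between measured compounds is available, so the expectation rests on the two values alone. Since compound 1 gave 20 ug/mL and compound 2 gave 20 ug/mL despite a different substituent on that ring, the step of no change at the digits printed from compound 2 to compound 3 (within the scatter) is expected to be none beyond the scatter. For compound 3 the value in this assay is estimated at 20 ug/mL, with a range from 10 ug/mL to 50 ug/mL.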

Compound 3, minimum cytotoxic concentration: 20 ug/mL
Beside the measured number, compound 3's estimate shows no gap at the digits printed; measured number inside the range.
By their numbers in this assay, from the lowest: compounds 1, 2 and 3 (each within the scatter of the next).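

Replacing 4-hydroxyphenyl with 2-hydroxyphenyl on a carbon with a double bond to nitrogen gives no change at the digits printed from compound 2 to compound 3 (within the scatter) in this assay. Compound 1 and compound 2 differ in more than one place, so they could not isolate the effect of moving the hydroxyl, whereas compound 2 and compound 3 differ only in where it sits on the ring. For this pair, the two hydroxyl placements cannot be told apart in this measure of tolerated concentration, and no supporting data explain why they read alike.

This result covers only these two hydroxyl placements on one core and in one cell assay, so it does not show whether the same holds for other groups on that ring, such as an amine or a carboxylic acid in place of the hydroxyl. It also leaves open whether a longer chain on the carbon with a double bond to nitrogen, in place of the saturated chain carbon found in compound 2 and compound 3, would alter the tolerated concentration.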